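Changing the Aryl Group on the Ring Nitrogen

A few compounds are considered here, and "the series" means these few. Any claim that something is new, unique, unknown or untested is made for them only; others in the source may bear on it.

Three compounds have been measured in a functional assay on MIA PaCa-2 cells (Homo sapiens) for inhibition, read by MTT assay, with a stated time of 72 h, tested at 50 uM; on this read-out lower numbers stand for less inhibition of growth and higher numbers for more inhibition of growth at the one concentration tested:

Compound 1, `C=CCc1ccc(OCc2cn(-c3ccccc3CO)nn2)c(O)c1`: 52.1%
Compound 2, `C=CCc1cc(O)c(O)c(CN2CCC(CO)CC2)c1`: 38.6%
Compound 3, `C=CCc1ccc(OCc2cn(-c3cc(OC)c(OC)c(OC)c3)nn2)c(O)c1`: 49.8%

Compound 1 has the highest of the three numbers. Compound 3 is within the usual scatter of it, so the two cannot be told apart; compound 2 sits beyond the scatter, clearly lower.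

Compound 4, `C=CCc1ccc(OCc2cn(-c3ccc(OC)cc3)nn2)c(O)c1`, has not yet been measured. It differs from compound 1 in one place: 4-methoxyphenyl in place of 2-(hydroxymethyl)phenyl on an aromatic nitrogen. The two compounds share the same atoms, joined differently, and the exchange happens on the aromatic nitrogen of the five-membered ring that bears the large group.

Among the compounds with values here, no pair of measured compounds differs in only one place, so no measured step guides this exchange. Compound 3, which carries a trimethoxyphenyl on the same aromatic nitrogen, is within the scatter of compound 1, which suggests that swapping the aryl group there makes little difference in this assay. The step is therefore expected to be small, in either direction or none beyond the scatter. Compound 4 is estimated at 48%, in the range 36% to 60%, which means an expected step of a number 4.1 percentage points lower from compound 1 to compound 4 (within the scatter).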

Compound 4, percent growth inhibition at one concentration: 88.2%
Estimate against measurement, compound 4: 40.2 percentage points below; the whole stated range lies below it.
By their numbers in this assay, from the lowest: compound 2; then compounds 3 and 1 (each within the scatter of the next); then compound 4.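

In this assay the exchange of 2-(hydroxymethyl)phenyl for 4-methoxyphenyl on the aromatic nitrogen gives a number 36.1 percentage points higher from compound 1 to compound 4 (beyond the scatter), so for this pair the aryl group on that nitrogen matters a great deal. The two groups match in heavy atoms, hydrogen-bond acceptors and the six-membered aromatic ring, yet the leaving group has a hydrogen-bond donor that the entering group lacks, and their single oxygen sits differently. Nothing measured here explains the rise.

On these data alone, it remains open whether the rise follows the methoxy group or its location, a question that 2-methoxyphenyl and 4-(hydroxymethyl)phenyl on the same nitrogen could separate. Also open, as far as these compounds go, is how an amine or a carboxylic acid in place of the methoxy group, as in 4-aminophenyl or 4-carboxyphenyl, would read in this assay.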